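From formyloxy to acetoxy: one small step

The source may report more compounds than this note shows. Statements on the series, on what has been measured and on what is new or still open speak of the compounds shown alone.

Compound 1 `OC1CCN(c2ccc(-c3cccc(Cl)c3)nn2)CC1` gives 45 mg/kg
Compound 2 `CCCC(=O)OC1CCN(c2ccc(-c3ccccc3Cl)nn2)CC1` gives 28 mg/kg
Compound 3 `O=COC1CCN(c2ccc(-c3ccc(Cl)cc3Cl)nn2)CC1` gives 24 mg/kg

All three compounds were tested in a functional assay on the whole organism with Mus musculus as the target, in the maximal electroshock model; on this read-out lower numbers stand for an effect already at smaller amounts and higher numbers for an effect only at larger amounts of compound. On this read-out, compound 3 at 24 mg/kg lies within the scatter of both compound 2 and compound 1, so the three numbers do not separate.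

Compound 4 `CC(=O)OC1CCN(c2ccc(-c3ccc(Cl)cc3Cl)nn2)CC1` shares the core of compound 3 and differs from it in one place, on a carbonyl carbon: methyl in place of hydrogen on a carbonyl carbon. This is methyl in place of hydrogen, which turns formyloxy to acetoxy. Among the compounds with values here, no measured pair differs in one place only, so the data offer no direct precedent for this change. Within the data shown here, compound 2, which also carries an ester, gives 28 mg/kg and thus provides the only indirect guide. No clear direction can be drawn from it. The estimated 1.0-fold higher number from compound 3 to compound 4 (0.02 log units; within the scatter) is expected to stay within the scatter. Compound 4 is expected at 25 mg/kg, with an estimated range of 13 mg/kg to 48 mg/kg.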

Compound 4, dose for half-maximal effect: 14 mg/kg
For compound 4 the middle estimate is 1.8-fold (0.25 log units) above the measured one; the measured number falls inside the stated range.
By their numbers in this assay, from the lowest: compounds 4, 3, 2 and 1 (each within the scatter of the next, the first and the last beyond it).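

Within the data shown here, compound 3 and compound 4 form the first pair here that differs in one place only, so methyl in place of hydrogen on a carbonyl carbon can now be read directly rather than inferred from compounds that differ elsewhere as well. In this assay this change gives a 1.7-fold lower number from compound 3 to compound 4 (0.23 log units; within the scatter) and so formyloxy and acetoxy do not separate at this position on the shared core. No measurement available here bears on how the two esters relate beyond these numbers.

On these data alone, what stays open is how this position would read with something other than these two esters on the same core, such as a carbamate, an amide or a benzoyloxy group. As far as these compounds go, it is also open whether an amine or a carboxylic acid at this place would keep a number in the same range.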